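Demethylating the methoxyphenyl ketone of a chalcone

The source may hold more compounds than are shown below. What is called first, only, known or untested is meant among the compounds shown, and "the series" means these compounds.

Compound 1 `COc1ccc(C(=O)/C=C/c2cc(OC)c(OC)cc2OC)cc1` gives 33900 nM in a functional assay on MCF7 cells (Homo sapiens) for inhibition, read by MTT assay, with a stated time of 72 h; on this read-out higher numbers stand for weaker inhibition and lower numbers for stronger inhibition.
Compound 3 `COc1cc(OC)c(OC)cc1/C=C/C(=O)c1ccc(Cl)c([N+](=O)[O-])c1` gives 16400 nM in this assay.
Compound 2 `COc1cc(OC)c(-c2cc(=O)c3ccc(O)cc3o2)cc1OC` reaches only the limit > 150000 nM in this assay; this is a limit of the measurement, not a number (the limit of > 150000 nM in this assay, at which 1 of the 3 values shown sits).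

Of the two numbers in this assay, compound 1 holds the higher one, with compound 3 lower. Compound 4 `COc1cc(OC)c(OC)cc1/C=C/C(=O)c1ccc(O)cc1` changes compound 1 in one place: hydrogen in place of methyl on an oxygen on an aromatic ring. Going by the values given here, no measured pair shows this kind of change, so the step is taken as small, in either direction, or none beyond the scatter. Compound 4 is expected to sit close to compound 1, with the step of a 1.4-fold lower number from compound 1 to compound 4 (0.13 log units; within the scatter) estimated at the edge of the scatter. Compound 4 is therefore estimated at 25000 nM, within 8000 nM to 80000 nM.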

Compound 4, half-maximal inhibitory concentration: 182000 nM
For compound 4 the middle estimate is 7.3-fold (0.86 log units) below the measured one; the whole stated range lies below it.
By their numbers in this assay, from the lowest: compound 3; then compound 1; then compound 4.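

Replacing methoxy with hydroxy on this aromatic ring is not a neutral change in this assay: it gives a 5.4-fold higher number from compound 1 to compound 4 (0.73 log units; beyond the scatter), so inhibition weakens. The methyl on this oxygen therefore matters, and the bare hydrogen does not stand in for it. The only other entry at this weak end of the series is a limit and not a number, held by compound 2: the limit of > 150000 nM in this assay, at which 1 of the 4 values shown sits.

From the compounds shown here alone, whether an ethoxy group or an amine at this place would keep the number of compound 1 stays open. So does whether the same change would cost as much on the ketone ring of compound 3.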